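Cytotoxicity limit in the series: compound 3 to compound 4

The compounds below may be only part of what the source reports. "The series", "measured", "known", "first", "only" and "open" are said of these compounds alone.

In an ADME assay on RAW264.7 cells (Mus musculus) for cytotoxicity, read by MTT assay (a lower number here means a stronger inhibitor, a higher number a weaker inhibitor), compound 1 (`CCCCCCCCC(CCCCCC)CCOc1cccc(O)c1C(=O)/C=C/c1ccc(O)cc1`) gives > 30000 nM as its reading, a limit of the assay and not a number. Compound 2 (`CCCCCCCCCCCCCCOc1ccc(C(=O)/C=C/c2ccc(O)cc2)c(O)c1`) gives > 30000 nM as its reading, again a limit and not a number. Compound 3 (`CCCCCCCCCCOc1cccc(O)c1C(=O)/C=C/c1ccc(O)c(Cl)c1`) gives > 30000 nM as its reading, also a limit and not a number. Going by the values given here, compound 3 therefore has no number of its own, and the series so far stands at the limit of > 30000 nM in this assay, at which 3 of the 3 values shown sit, with no measured step.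

Compound 4 (`CCCCCCCCCCOc1cccc(O)c1C(=O)/C=C/c1ccc(OC)cc1`) carries 4-methoxyphenyl in place of 3-chloro-4-hydroxyphenyl on a double-bonded chain carbon bound to a double-bonded chain carbon.

No change beyond the scatter and no direction is expected in this assay and the estimated step is a number no higher from compound 3 to compound 4 (the limit leaves the size open) on that basis. This expectation rests only on the limit of > 30000 nM in this assay, at which 3 of the 3 values shown sit, as the shared position of the series. Compound 4 is expected at 30000 nM with an estimated range from 15000 nM to 60000 nM and a reading given only as a limit is likely.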

Compound 4, half-maximal inhibitory concentration: > 30000 nM
Compound 4: no number, only a limit; the forecaster's own chance of this, stated with the estimate: 85%; the middle value sits exactly at the limit.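

Compound 3 and compound 4 both sit at a limit and not at a number, so no step between them can be read; the series holds one shared position: the limit of > 30000 nM in this assay, at which 4 of the 4 values shown sit.

The compounds shown leave open which structural change, if any, would give a numerical reading in this assay.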